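Replacing a long ester-bearing side chain with sec-butyl

A few compounds are considered here, and "the series" means these few. Any claim that something is new, unique, unknown or untested is made for them only; others in the source may bear on it.

Three compounds share a core and are measured in a functional assay on the whole organism (Tail, strain ICR) with Mus musculus as the target, in the tail flick test, with a stated time of 120 min, at a dose of 25 umol/kg by the oral route; a lower number here means a weaker effect, a higher number a stronger effect of the compound at the dose given. Compound 1 `C[C@H](NC(=O)CN(c1nc(Cl)nc2[nH]cnc12)C1CC1)C(=O)OCc1ccccc1` gives 36.1%. Compound 3 `C[C@@H](O)[C@H](NC(=O)CN(c1nc(Cl)nc2[nH]cnc12)C1CC1)C(=O)OCc1ccccc1` gives 30.7%, and the step of a number 5.4 percentage points lower from compound 1 to compound 3 (within the scatter) shows how little this change alters the read-out. Compound 2 `O=C(CN(c1ncnc2c1ncn2C1CCCCO1)C1CC1)N[C@@H](CCC(=O)OCc1ccccc1)C(=O)OCc1ccccc1` gives 20.7%, the lowest of the three numbers, though its gap to compound 3 lies within the scatter; only its gap to compound 1 lies beyond it.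

Compound 4 `CC[C@H](C)[C@H](NC(=O)CN(c1ncnc2c1ncn2C1CCCCO1)C1CC1)C(=O)OCc1ccccc1` differs from compound 2 by sec-butyl in place of 2-(benzyloxycarbonyl)ethyl on a saturated chain carbon bound to an amide-type nitrogen and a carbonyl carbon. Within the data shown here, no measured step covers this particular exchange. Among the measured compounds shown here, the only step at the same place, from compound 1 to compound 3, stayed within the scatter, so there is no measured ground for expecting a large change in this assay. Compound 1, which also carries a small alkyl group at this position, sits higher than compound 2, which gives some reason to expect a modest rise.

Compound 4 is therefore estimated to give 28%, with a range from 12% to 45%. That expectation corresponds to a step of a number 7.3 percentage points higher from compound 2 to compound 4 (within the scatter).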

Compound 4, a percentage reported as activity, at one dose (the size of the read-out at that dose, not a potency): 20.4%
Beside the measured number, compound 4's estimate is 7.6 percentage points above it; the range from low to high includes it.
By their numbers in this assay, from the lowest: compounds 4, 2, 3 and 1 (each within the scatter of the next, the first and the last beyond it).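

On the core of compound 2, sec-butyl in place of 2-(benzyloxycarbonyl)ethyl gives a number 0.3 percentage points lower from compound 2 to compound 4 (within the scatter) in this assay even though the exchange removes a six-membered aromatic ring and two hydrogen-bond acceptors and shrinks the group from 12 heavy atoms to 4. Among these compounds, the earlier step at this place, 1-hydroxyethyl for methyl on the core of compound 1, was a far smaller exchange, so this is the first sign that a large change at this carbon can also stay inside the scatter. Nothing shown here offers an explanation for this.

The compounds shown leave open how a side chain ending in a carboxylic acid or an amine would read at this carbon, and whether sec-butyl would behave the same way on the core of compound 1. They also leave open whether this picture holds at other doses or times.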